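The compounds below may be only part of what the source reports. "The series", "measured", "known", "first", "only" and "open" are said of these compounds alone.

Of the compounds shown here, three built on one shared core have been measured in a functional assay on MCF7 cells (Homo sapiens) for cytotoxicity, read by MTT assay, with a stated time of 48 h; a higher number here means a weaker inhibitor, a lower number a stronger inhibitor. Compound 1 `O=C(Nc1nc2ccc(Cl)cc2s1)c1cc(-c2ccc(F)cc2)n2nc(-c3ccccc3)cc2n1` gives 19800 nM. Compound 2 `COc1ccc(-c2cc(C(=O)Nc3nc4ccc(Cl)cc4s3)nc3cc(-c4ccccc4)nn23)cc1OC` gives 6910 nM, and compound 3 `COc1cc(-c2cc(C(=O)Nc3nc4ccc(Cl)cc4s3)nc3cc(-c4ccccc4)nn23)cc(OC)c1OC` gives 30200 nM. Among these three numbers compound 1 stands second highest. The step of a 2.9-fold lower number from compound 1 to compound 2 (0.46 log units; beyond the scatter), while the step of a 1.5-fold higher number from compound 1 to compound 3 (0.18 log units; within the scatter). Between the two methoxy-bearing compounds the step of a 4.4-fold higher number from compound 2 to compound 3 (0.64 log units; beyond the scatter).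

Compound 4 `O=C(Nc1nc2ccc(F)cc2s1)c1cc(-c2ccc(F)cc2)n2nc(-c3ccccc3)cc2n1` has not yet been measured in this assay. It differs from compound 1 in a single place: fluoro in place of chloro on an aromatic carbon. None of the three measured steps touches this part of the molecule; each of them exchanged the aryl group on the other side of the core and left the halogen on the fused ring untouched. So no measured step bears directly on the change from compound 1 to compound 4, and the data give no reason to expect the number to move in either direction. The expectation is therefore a step of a 1.0-fold higher number from compound 1 to compound 4 (0.00 log units; within the scatter), which is none beyond the scatter. On that basis compound 4 is estimated at 20000 nM, with a range from 8000 nM to 50000 nM.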

Compound 4, half-maximal inhibitory concentration: 22900 nM
The estimate for compound 4 lay 1.1-fold (0.06 log units) below the measured number; the range from low to high includes it.
By their numbers in this assay, from the lowest: compound 2; then compounds 1, 4 and 3 (each within the scatter of the next).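

In this assay the exchange of chloro for fluoro gives a 1.2-fold higher number from compound 1 to compound 4 (0.06 log units; within the scatter) and so stays inside the normal noise of the measurement: going from the 6-chloro-1,3-benzothiazol-2-yl group to the 6-fluoro-1,3-benzothiazol-2-yl group produces no readable shift. This is the only step shown that touches this halogen, whereas the other three steps all exchanged the aryl group, and two of those went beyond the scatter, so this position now has a first reading of its own, though that reading holds only for this one pair of halogens on the core of compound 1. Nothing available here explains why the two compounds read alike.

From the compounds shown here alone, whether a hydrogen, a methoxy group, an amine or a nitrile in place of the halogen would leave the number just as unmoved remains open. Going by these compounds, it is also open whether the same exchange of chloro for fluoro would read alike when the core carries the 3,4-dimethoxyphenyl group of compound 2 instead of the 4-fluorophenyl group.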